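Swapping a Hydroxyphenyl Ketone for a Benzyloxy Group

The compounds below may be only part of what the source reports. "The series", "measured", "known", "first", "only" and "open" are said of these compounds alone.

Compound 1 `Cc1cc(Oc2ccc(C(=O)c3ccc(O)cc3)cc2)nc(Nc2ccc(C#N)cc2)n1` and compound 2 `Cc1cc(Oc2ccc(OCc3ccccc3)cc2)nc(Nc2ccc(C#N)cc2)n1` share one core, while compound 3 `Cc1cnc(Nc2ccc(C#N)cc2)nc1Oc1ccc(C(=O)c2ccc(O)cc2)cc1` is built from the same atoms as compound 1, joined differently; the difference between the two cores is not broken down here. Compound 4 `Cc1cnc(Nc2ccc(C#N)cc2)nc1Oc1ccc(OCc2ccccc2)cc1` has not yet been measured.

In an ADME assay on MT4 cells (Homo sapiens) for cytotoxicity, read by MTT assay, with a stated time of 5 days (on this read-out lower numbers stand for higher toxicity in this test and higher numbers for lower toxicity in this test), compound 1 gives 32000 nM and compound 2 gives 27700 nM. The change between them is benzyloxy in place of (4-hydroxyphenyl)carbonyl on an aromatic carbon, and it made a 1.2-fold lower number from compound 1 to compound 2 (0.06 log units; within the scatter).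

In this assay compound 3 gives only a limit, > 295000 nM. That value is the limit of > 295000 nM in this assay, at which 1 of the 3 values shown sits.

From compound 3 to compound 4 the same change is made, (benzyloxy in place of (4-hydroxyphenyl)carbonyl on an aromatic carbon). Because the earlier step was a 1.2-fold lower number from compound 1 to compound 2 (0.06 log units; within the scatter), a similarly small step is expected here, so that compound 4 is estimated to sit near the limit reached by compound 3, with an expected step of an at least 1.1-fold lower number from compound 3 to compound 4 (0.07 log units; that floor lies within the scatter). On that basis compound 4 is expected to give about 250000 nM, most likely between 100000 nM and 400000 nM, with a fair chance that this assay again reports only a limit.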

Compound 4, half-maximal cytotoxic concentration: 170000 nM
Beside the measured number, compound 4's estimate is 1.5-fold (0.17 log units) above it, and the stated range covers the measured number.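

In this assay the same swap on the second core gives an at least 1.7-fold lower number from compound 3 to compound 4 (0.23 log units; that floor lies within the scatter) and neither this floor nor the earlier step on the first core lies beyond the usual scatter of repeated measurements. So nothing here shows the change acting differently on the two cores, yet nothing shows it acting alike either: the same change on two cores in this assay, a 1.2-fold lower number (0.06 log units; within the scatter) from compound 1 to compound 2 and an at least 1.7-fold lower number (0.23 log units; that floor lies within the scatter) from compound 3 to compound 4; the limit leaves it open whether they differ. Going by these compounds, the true size of the second step stays unknown, since compound 3 has only a limit and not a number: the limit of > 295000 nM in this assay, at which 1 of the 4 values shown sits.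

Only benzyloxy and (4-hydroxyphenyl)carbonyl appear at this place, so the compounds shown leave open how an amine or a carboxylic acid there would read on either core. They also leave open whether a longer chain ending in the same ring would give similar steps on both cores, a question that needs a number rather than a limit for every compound compared.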